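A few compounds are considered here, and "the series" means these few. Any claim that something is new, unique, unknown or untested is made for them only; others in the source may bear on it.

Working notes on the series. In a functional assay on CCRF-CEM cells (Homo sapiens), read by MTT assay, with a stated time of 72 h (a higher number here means a weaker inhibitor, a lower number a stronger inhibitor), compound 1 `Cc1ncnc2c1c(I)cn2[C@@H]1O[C@H](CO)[C@@H](O)[C@H]1O` gives 5480 nM. Compound 2 `C#Cc1cn([C@@H]2O[C@H](CO)[C@@H](O)[C@H]2O)c2ncnc(C)c12` gives 5600 nM in this assay, and the step of a 1.0-fold lower number from compound 2 to compound 1 (0.01 log units; within the scatter) shows the two values within the usual scatter of each other. Compound 3 `C#Cc1cn([C@@H]2O[C@H](CO)[C@@H](O)[C@H]2O)c2ncnc(OC)c12` keeps the ethynyl of compound 2, but its core differs from the core of compound 2 by methoxy in place of methyl on an aromatic carbon. For compound 3, this assay returns only a limit, > 20000 nM. The step of an at least 3.5-fold higher number from compound 2 to compound 3 (0.55 log units; beyond the scatter) is bounded by the limit of > 20000 nM in this assay, at which 1 of the 3 values shown sits, and not fixed as a number.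

Compound 4 `COc1ncnc2c1c(I)cn2[C@@H]1O[C@H](CO)[C@@H](O)[C@H]1O` is not yet measured in this assay. It differs from compound 3 by iodo in place of ethynyl on an aromatic carbon. Within the data shown here, that is the same change as the one from compound 2 to compound 1, (iodo in place of ethynyl on an aromatic carbon), since the two descriptions of the place are identical, and there the step was a 1.0-fold lower number from compound 2 to compound 1 (0.01 log units; within the scatter). Because a 1.0-fold lower number from compound 2 to compound 1 (0.01 log units; within the scatter) sits within the scatter, the step to compound 4 is expected to be about a step that the limit leaves unreadable from compound 3 to compound 4. Compound 4 is accordingly estimated at 25000 nM in this assay, with the range 10000 nM to 60000 nM, and a limit rather than a number is the more likely outcome.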

Compound 4, half-maximal inhibitory concentration: 1150 nM
Estimate against measurement, compound 4: 22-fold (1.34 log units) above; measured number outside the range, below it.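

On the core of compound 3, iodo in place of ethynyl gives an at least 17-fold lower number from compound 3 to compound 4 (1.24 log units; beyond the scatter), and this step does not carry over from the core of compound 2: the same change on two cores in this assay, a 1.0-fold lower number (0.01 log units; within the scatter) from compound 2 to compound 1 and an at least 17-fold lower number (1.24 log units; beyond the scatter) from compound 3 to compound 4, at least 17-fold (1.23 log units) apart, beyond the scatter of two such steps

With iodo on the aromatic carbon, methoxy in place of methyl gives a 4.8-fold lower number from compound 1 to compound 4 (0.68 log units; beyond the scatter), which runs the opposite way to the same change with ethynyl there, so neither change can be carried from one core to the other in these four compounds as a fixed step: the same change on two cores in this assay, an at least 3.5-fold higher number (0.55 log units; beyond the scatter) from compound 2 to compound 3 and a 4.8-fold lower number (0.68 log units; beyond the scatter) from compound 1 to compound 4, at least 17-fold (1.23 log units) apart, beyond the scatter of two such steps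

Compound 3 is known only through a limit, so the exact size of both gaps stays unfixed, and the data show that the two changes depend on each other but not why: the limit of > 20000 nM in this assay, at which 1 of the 4 values shown sits.

The compounds shown leave open whether this dependence extends to other groups on that aromatic carbon, such as bromo, chloro or a longer propynyl chain. They also leave open how an amine or an ethoxy group would behave in place of the methyl or methoxy on the shared core.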